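Capping the phenol: methyl on the oxygen of compound 1

This account rests on a few compounds, and the source may have more. Where it says the series, first, only, none or still open, it means among the compounds named here.

Measured so far:
- Compound 1, `O=C(O)c1c(O)cc(Cl)cc1C=Cc1ccc2ccccc2c1`: 25000 nM
- Compound 2, `O=C(O)c1c(O)cccc1C=Cc1ccc2ccccc2c1`: 71000 nM

In an ADME assay on HepG2 cells (Homo sapiens) for cytotoxicity, read by resazurin assay, with a stated time of 24 h (a higher number here means that more compound is tolerated, a lower number that less compound is tolerated), compound 1 stands lowest of the two measured numbers, so of the pair it is the less well tolerated one; compound 2 is the nearer neighbour and lies a 2.8-fold higher number from compound 1 to compound 2 (0.45 log units; beyond the scatter) above it.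

Compound 3, `COc1cc(Cl)cc(C=Cc2ccc3ccccc3c2)c1C(=O)O`, is not yet measured. It differs from compound 1 by methyl in place of hydrogen on an oxygen on an aromatic ring, which, read one bond further out, is a hydroxy turning into a methoxy. The chloro group of compound 1 is kept.

Going by the values given here, the only measured step, a 2.8-fold higher number from compound 1 to compound 2 (0.45 log units; beyond the scatter), concerns the chloro group and not the oxygen, so it gives no direct guide to this change. With nothing in the data to point either way, a step in this assay no larger than the usual scatter is expected, in no firm direction. Compound 3 is therefore estimated at 30000 nM, within 10000 nM to 90000 nM, which would mean a 1.2-fold higher number from compound 1 to compound 3 (0.08 log units; within the scatter).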

Compound 3, half-maximal cytotoxic concentration: 104000 nM
The estimate for compound 3 lay 3.5-fold (0.54 log units) below the measured number; measured number outside the range, above it.
By their numbers in this assay, from the lowest: compound 1; then compounds 2 and 3 (each within the scatter of the next).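

In this assay, the oxygen on the aromatic ring of compound 1 proves to be a place where a very small change counts: methyl in place of the hydrogen, which turns a hydroxy into a methoxy, gives a 4.2-fold higher number from compound 1 to compound 3 (0.62 log units; beyond the scatter) with the chloro group kept. The earlier pair differed only at the chloro group, so it could not show that this oxygen also affects how much compound the cells tolerate. Nothing available explains why the number moves with this change.

Going by these compounds, the methoxy appears here only together with the chloro group, so it remains open whether the same change would shift the number without that group. Also open, on these data alone, is how a longer chain such as ethyl on this oxygen, or an amine in place of the methoxy, would read in this assay.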